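Removing a methoxy group from an indole-based cytotoxic series

The source may report more compounds than this note shows. Statements on the series, on what has been measured and on what is new or still open speak of the compounds shown alone.

Compound 1 `COc1ccc2[nH]c(-c3ccccc3)c(C(c3c(-c4ccccc4)[nH]c4ccc(Cl)cc34)C3C(=O)NN=C3C)c2c1` and compound 2 `CC1=NNC(=O)C1C(c1c(-c2ccccc2)[nH]c2ccccc12)c1c(-c2ccccc2)[nH]c2ccc(Cl)cc12` were both tested in a functional assay on HEp-2 cells (Homo sapiens) for cytotoxicity, read by MTT assay; on this read-out lower numbers stand for stronger inhibition and higher numbers for weaker inhibition. Compound 1 gives 6200 nM, while compound 2 gives 41700 nM. The two differ in one place only: hydrogen in place of methoxy on an aromatic carbon. That change brought a 6.7-fold higher number from compound 1 to compound 2 (0.83 log units; beyond the scatter), so the loss of the methoxy group weakened the effect.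

Compound 3 `COc1ccc2[nH]c(-c3ccccc3)c(C(c3c[nH]c4ccccc34)C3C(=O)NN=C3C)c2c1` carries a different core; the difference between the core of compound 1 and the core of compound 3 is not broken down here. In this assay compound 3 gives 5300 nM, a value that lies within the scatter of compound 1.

Compound 4 `CC1=NNC(=O)C1C(c1c[nH]c2ccccc12)c1c(-c2ccccc2)[nH]c2ccccc12` has not yet been measured. It differs from compound 3 in the same way: hydrogen in place of methoxy on an aromatic carbon. The place of the change is the same as before, so this is the same change. Going by the values given here, only one earlier example of it exists, so the expectation rests on a single step. Because the earlier change gave a 6.7-fold higher number from compound 1 to compound 2 (0.83 log units; beyond the scatter), compound 4 is expected to show a step of a 4.7-fold higher number from compound 3 to compound 4 (0.67 log units; beyond the scatter). In this assay compound 4 is estimated at 25000 nM, most likely between 8000 nM and 80000 nM.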

Compound 4, half-maximal inhibitory concentration: 6700 nM
Beside the measured number, compound 4's estimate is 3.7-fold (0.57 log units) above it, and the stated range ends above it.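

On the core of compound 3, putting hydrogen in place of methoxy leaves no readable difference in this assay, with a 1.3-fold higher number from compound 3 to compound 4 (0.10 log units; within the scatter). The same change therefore does not have the same size on both cores in this series: the same change on two cores in this assay, a 6.7-fold higher number (0.83 log units; beyond the scatter) from compound 1 to compound 2 and a 1.3-fold higher number (0.10 log units; within the scatter) from compound 3 to compound 4, 5.3-fold (0.73 log units) apart, beyond the scatter of two such steps

This shows that the loss of effect seen on the core of compound 1 cannot simply be assumed on another core, so a single step is a weak guide here. Going by these compounds alone, with only two pairs, it does not show why the cores differ or which part of a core decides the outcome.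

The compounds shown have only methoxy or hydrogen at this place, so it remains open how another group, such as an amine, a carboxylic acid or a longer chain like ethoxy, would behave there on either core. Going by these compounds, it also remains open whether a further core would follow the pair of compound 1 and compound 2 or the pair of compound 3 and compound 4.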